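Swapping the benzyl substituent on a cell-growth inhibitor series

The compounds below may be only part of what the source reports. "The series", "measured", "known", "first", "only" and "open" are said of these compounds alone.

Measured so far:
- compound 1, `Fc1ccccc1COc1ccccc1/C=C/C(/C=C/c1ccccn1)=N/Oc1ncnc2cc(Cl)ccc12`, 94.8%
- compound 2, `Fc1ccccc1COc1ccc(/C=C/C(/C=C/c2ccccn2)=N/Oc2ncnc3cc(Cl)ccc23)cc1`, 91.2%
- compound 3, `Clc1ccc(COc2ccc(/C=C/C(/C=C/c3ccccn3)=N/Oc3ncnc4ccccc34)cc2)cc1`, 94.4%

All three were tested in a functional assay on SMMC-7721 cells (Homo sapiens) for inhibition, read by MTT assay, with a stated time of 72 h, tested at 10 uM; on this read-out lower numbers stand for a weaker effect and higher numbers for a stronger effect at the one concentration tested. In this assay compound 1 gives 94.8%, compound 2 gives 91.2% and compound 3 gives 94.4%. Compound 2 lies within the scatter of both compound 1 and compound 3, so nothing separates the three on these numbers; each shows strong inhibition at the single concentration tested.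

The next compound is compound 4, `Cc1cccc(COc2ccc(/C=C/C(/C=C/c3ccccn3)=N/Oc3ncnc4cc(Cl)ccc34)cc2)c1`. It differs from compound 2 in one place: 3-methylphenyl in place of 2-fluorophenyl on a saturated chain carbon bound to an oxygen on an aromatic ring. The three measured compounds already carry different groups on the same saturated chain carbon and give numbers within the scatter of each other, which gives no basis to expect a step beyond the scatter in this assay, in either direction. Compound 4 is therefore expected to give 92%, in the range 80% to 98%, an estimated step of a number 0.8 percentage points higher from compound 2 to compound 4 (within the scatter).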

Compound 4, a percentage reported as inhibition, at one concentration (the size of the read-out at that concentration, not a potency): 95.6%
For compound 4 the middle estimate is 3.6 percentage points below the measured one; the measured number falls inside the stated range.
By their numbers in this assay, from the lowest: compounds 2, 3, 1 and 4 (each within the scatter of the next).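

In this assay, placing 3-methylphenyl in place of 2-fluorophenyl on a saturated chain carbon bound to an oxygen on an aromatic ring gives a number 4.4 percentage points higher from compound 2 to compound 4 (within the scatter). Going by these compounds alone, this is the first comparison here in which only one place changes, so the swap can be read without other differences in the molecule, and it shows no separable effect on inhibition at the concentration tested. No measurement at hand speaks to the reason for this result.

With only one concentration and all four numbers high on the scale, any difference in potency between these compounds remains unresolved. As far as these compounds go, it also remains open whether an amine, a carboxylic acid or a longer chain in place of the substituted phenyl ring would leave the inhibition unchanged.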